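Shortening the amine on the chain: a second look

The source may report more compounds than this note shows. Statements on the series, on what has been measured and on what is new or still open speak of the compounds shown alone.

Compound 1 `CCN(CC)CCn1c(N)c(-c2nc3ccccc3[nH]2)c2nc(C#N)c(C#N)nc21` and compound 2 `CN(C)CCCn1c(N)c(-c2nc3ccccc3[nH]2)c2nc(C#N)c(C#N)nc21` share one core, while compound 3 `CCN(CC)CCCn1c(N)c(-c2nc3ccccc3n2C)c2nc(C#N)c(C#N)nc21` and compound 4 `CN(C)CCCCn1c(N)c(-c2nc3ccccc3n2C)c2nc(C#N)c(C#N)nc21` share another; the difference between the two cores is not broken down here. In a functional assay on cells (Homo sapiens) for antiproliferative activity, read by MTT assay, with a stated time of 48 h (a lower number here means a stronger inhibitor, a higher number a weaker inhibitor), compound 1 gives 25400 nM, and compound 2 gives 1820 nM. That change, ((dimethylamino)methyl in place of diethylamino on a saturated chain carbon, two bonds along the chain from an aromatic nitrogen), produced a 14-fold lower number from compound 1 to compound 2 (1.14 log units; beyond the scatter). Compound 3 gives 6750 nM in this assay, a number standing between those of compound 1 and compound 2.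

Compound 4 carries the change ((dimethylamino)methyl in place of diethylamino on a saturated chain carbon, three bonds along the chain from an aromatic nitrogen). It is the same kind of change as that from compound 1 to compound 2, but the place differs: there the group sits two bonds along the chain from an aromatic nitrogen, here three bonds along the chain from an aromatic nitrogen. For the measured compounds named here, since the only measured example of this change is a 14-fold lower number from compound 1 to compound 2 (1.14 log units; beyond the scatter) from compound 1 to compound 2, a step of similar direction but more cautious size, a 5.2-fold lower number from compound 3 to compound 4 (0.72 log units; beyond the scatter), is expected for compound 4. The core and the place are not identical, and the expected step is held to a smaller size for that. Compound 4 is therefore estimated at 1300 nM, with a range from 400 nM to 5000 nM.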

Compound 4, half-maximal inhibitory concentration: 1790 nM
For compound 4 the middle estimate is 1.4-fold (0.14 log units) below the measured one; measured number inside the range.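

In this assay the change lowers the number again, with a 3.8-fold lower number from compound 3 to compound 4 (0.58 log units; beyond the scatter) on the second core, so its direction is the same in both pairs shown. Its size does not carry over unchanged, as the two steps differ by more than the usual scatter: the same change on two cores in this assay, a 14-fold lower number (1.14 log units; beyond the scatter) from compound 1 to compound 2 and a 3.8-fold lower number (0.58 log units; beyond the scatter) from compound 3 to compound 4, 3.7-fold (0.57 log units) apart, beyond the scatter of two such steps. For the compounds shown here, these are only two pairs that differ in both the core and the place of the change on the chain, so they do not show whether the core, the place or both set the size of the step, and they give no general rule for the series.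

The compounds shown leave open how large the step would be on each core with the change at one and the same place on the chain. They also leave open whether the direction would hold with a longer chain, or with a dipropylamino group in place of the diethylamino group.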